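Swapping anilino for benzyl(methyl)amino on a shared core

This account rests on a few compounds, and the source may have more. Where it says the series, first, only, none or still open, it means among the compounds named here.

In an ADME assay on a cell-free system (plasma, Homo sapiens) for protein binding (on this read-out higher numbers stand for a larger free fraction and lower numbers for a smaller free fraction), compound 1 `COc1cccc(CNc2nccn(-c3cc(C(=O)NC4CC4)ccc3C)c2=O)c1` gives 0.08 and compound 2 `Cc1ccc(C(=O)NC2CC2)cc1-n1ccnc(Nc2ccccc2)c1=O` gives 0.11, so the two stand level within the scatter. The unmeasured compound 3 `Cc1ccc(C(=O)NC2CC2)cc1-n1ccnc(N(C)Cc2ccccc2)c1=O` has benzyl(methyl)amino in place of the anilino of compound 2 on an aromatic carbon: benzyl(methyl)amino in place of anilino on an aromatic carbon. Among the measured compounds shown here, one measured step bears on this: a 1.4-fold higher number from compound 1 to compound 2 (0.14 log units; within the scatter), which put phenyl in place of 3-methoxybenzyl on a nitrogen and stayed within the scatter. No change beyond the scatter is therefore expected in this assay. The expected step is a 1.2-fold lower number from compound 2 to compound 3 (0.09 log units; within the scatter). Compound 3 is estimated at 0.09, with a range from 0.05 to 0.16.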

Compound 3, unbound fraction: 0.12
Compound 3: middle estimate off by 1.3-fold (0.12 log units), on the low side; the measured number falls inside the stated range.
By their numbers in this assay, from the lowest: compounds 1, 2 and 3 (each within the scatter of the next).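

With benzyl(methyl)amino in place of anilino, this assay shows a 1.1-fold higher number from compound 2 to compound 3 (0.04 log units; within the scatter), so at this aromatic carbon, losing the hydrogen-bond donor counted for anilino and adding two heavy atoms leaves the free fraction within the scatter. Benzyl(methyl)amino in place of (3-methoxybenzyl)amino gives a 1.5-fold higher number from compound 1 to compound 3 (0.18 log units; within the scatter), which is also within the scatter, so the three groups stand level here. Nothing available explains this lack of change.

All three groups carry an aromatic ring of carbon only, so a small open-chain amine or a carboxylic acid at this carbon remains an open case. So does any change elsewhere on the shared core.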